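The source may report more compounds than this note shows. Statements on the series, on what has been measured and on what is new or still open speak of the compounds shown alone.

Measured so far in an in vitro ADME assay on microsomes from liver (Homo sapiens) for pharmacokinetics, read by LC-MS, with a stated time of 10 min, tested at 1 uM (a higher number here means faster removal of the compound, a lower number slower removal), for three compounds:
Compound 1 `CN1C[C@H](C(=O)Nc2ccc(C#N)cc2)[C@@H](c2ccc(/C=C/C(=O)Nc3ccccc3N)cc2)C1` gives 1 mL/min/kg
Compound 2 `CN1C[C@H](C(=O)Nc2ccc(F)cc2F)[C@@H](c2ccc(/C=C/C(=O)Nc3ccccc3N)cc2)C1` gives 12 mL/min/kg
Compound 3 `CN1C[C@H](C(=O)Nc2ccccn2)[C@@H](c2ccc(/C=C/C(=O)Nc3ccccc3N)cc2)C1` gives 8 mL/min/kg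

Compound 3 belongs to the higher pair: the numbers show an 8.0-fold higher number from compound 1 to compound 3 (0.90 log units; beyond the scatter) as a real gap, and a 1.5-fold lower number from compound 2 to compound 3 (0.18 log units; within the scatter) as no real gap. Compound 4 `CN1C[C@H](C(=O)NC2CC2)[C@@H](c2ccc(/C=C/C(=O)Nc3ccccc3N)cc2)C1` keeps the shared core and carries cyclopropyl in place of pyridin-2-yl on an amide-type nitrogen. Swaps at this place have given a 12-fold higher number from compound 1 to compound 2 (1.08 log units; beyond the scatter) as a large move, yet also the small step above, and no measured compound holds a non-aromatic ring there. No direction can be drawn from these steps. The expected result is a 1.1-fold lower number from compound 3 to compound 4 (0.06 log units; within the scatter) as an estimated step, none beyond the scatter. Compound 4 is expected near 7 mL/min/kg (estimated range 2.5 mL/min/kg to 18 mL/min/kg).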

Compound 4, clearance: 10 mL/min/kg
The estimate for compound 4 lay 1.4-fold (0.15 log units) below the measured number, within the range that was stated.
By their numbers in this assay, from the lowest: compound 1; then compounds 3, 4 and 2 (each within the scatter of the next).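

In this assay, cyclopropyl, a non-aromatic ring on this amide-type nitrogen, stays with the higher group, the steps reading a 1.3-fold higher number from compound 3 to compound 4 (0.10 log units; within the scatter) and a 1.2-fold lower number from compound 2 to compound 4 (0.08 log units; within the scatter) as its two nearest neighbours. Only the 4-cyanophenyl group stands apart, with a 10-fold higher number from compound 1 to compound 4 (1.00 log units; beyond the scatter), so among these four compounds an aromatic ring at this place does not by itself give the low number. No measurement at hand gives a reason for these numbers. Still open, on these data alone, is whether an amine, a carboxylic acid or a longer chain on this nitrogen would stay with the higher group or come down towards compound 1.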